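The source may report more compounds than this note shows. Statements on the series, on what has been measured and on what is new or still open speak of the compounds shown alone.

Measured so far in a functional assay on RXF 393 cells (Homo sapiens) for inhibition, read by sulforhodamine B assay, with a stated time of 48 h; a higher number here means a weaker inhibitor of growth, a lower number a stronger inhibitor of growth:
compound 1 `COc1cc(-c2nn(-c3cccc(NC(=O)Nc4cc(C(F)(F)F)cc(C(F)(F)F)c4)c3)cc2-c2ccncc2)ccc1Cl` gives 869 nM
compound 2 `O=C(Nc1cccc(-n2cc(-c3ccncc3)c(-c3ccc(Cl)c(O)c3)n2)c1)Nc1cc(C(F)(F)F)cc(C(F)(F)F)c1` gives 937 nM
compound 3 `COc1cc(-c2nn(-c3cccc(NC(=O)Nc4ccc(Cl)c(C(F)(F)F)c4)c3)cc2-c2ccncc2)ccc1Cl` gives 1180 nM

The three numbers lie close together; none of the gaps between them is beyond the scatter. The change from compound 1 to compound 2 is hydrogen in place of methyl on an oxygen on an aromatic ring, and the step it made was a 1.1-fold higher number from compound 1 to compound 2 (0.03 log units; within the scatter). Compound 3 and compound 1 differ in more than one place; the difference between the two cores is not broken down here.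

Compound 4 `O=C(Nc1cccc(-n2cc(-c3ccncc3)c(-c3ccc(Cl)c(O)c3)n2)c1)Nc1ccc(Cl)c(C(F)(F)F)c1` is not yet measured in this assay. It differs from compound 3 by hydrogen in place of methyl on an oxygen on an aromatic ring, the same change at the same place as from compound 1 to compound 2. The step from compound 3 to compound 4 is expected to be of similar size, a 1.1-fold higher number from compound 3 to compound 4 (0.04 log units; within the scatter), since the same change gave a 1.1-fold higher number from compound 1 to compound 2 (0.03 log units; within the scatter). Compound 4 is estimated at 1300 nM, with a likely range from 650 nM to 2600 nM.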

Compound 4, concentration for 50% growth inhibition: 508 nM
Compound 4: middle estimate off by 2.6-fold (0.41 log units), on the high side, outside the stated range (below it).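

In this assay, methoxy to hydroxy on the aromatic ring gives a 2.3-fold lower number from compound 3 to compound 4 (0.37 log units; beyond the scatter), a modest step beyond the scatter. Set beside the earlier step on the core of compound 1, it does not separate from it: the same change on two cores in this assay, a 1.1-fold higher number (0.03 log units; within the scatter) from compound 1 to compound 2 and a 2.3-fold lower number (0.37 log units; beyond the scatter) from compound 3 to compound 4, 2.5-fold (0.40 log units) apart, within the scatter of two such steps. Going by these compounds alone, the change therefore carries across these two cores with no demonstrated dependence on the core, but two pairs do not establish a shared step size, and the only step beyond the scatter rests on a single pair.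

Still open, from the compounds shown here alone, is what an amine or an ethoxy group would give in place of the hydroxy. Also open, going by these compounds, is whether the step holds on a core carrying a nitrile in place of a trifluoromethyl.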